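The source may hold more compounds than are shown below. What is called first, only, known or untested is meant among the compounds shown, and "the series" means these compounds.

Of the compounds shown here, three built on one shared core have been tested in a functional assay on HCT-116 cells (Homo sapiens) for antiproliferative activity, read by MTT assay; a lower number here means a stronger inhibitor, a higher number a weaker inhibitor. Compound 1 `CNC(=O)c1ccc(Oc2cccc(NC(=S)Nc3ccc(C)cc3)c2)nc1` gives 53700 nM. Compound 2 `CNC(=O)c1ccc(Oc2cccc(NC(=S)Nc3ccc(F)c(F)c3)c2)nc1` gives 38200 nM, and compound 3 `CNC(=O)c1ccc(Oc2cccc(NC(=S)Nc3ccc(F)cc3)c2)nc1` gives 39400 nM. Compound 1 holds the highest of the three numbers, yet its distance to both neighbours lies within the scatter, so the three cannot be told apart on these data.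

Compound 4 `CNC(=O)c1ccc(Oc2cccc(NC(=S)Nc3ccc(F)c(Cl)c3)c2)nc1` is not yet measured. It differs from compound 1 in one place: 3-chloro-4-fluorophenyl in place of 4-methylphenyl on an amide-type nitrogen. Among the measured compounds shown here, two measured steps bear on this change. Putting fluoro in place of methyl on an aromatic carbon gave a 1.4-fold lower number from compound 1 to compound 3 (0.13 log units; within the scatter), and putting 3,4-difluorophenyl in place of 4-methylphenyl on the amide-type nitrogen gave a 1.4-fold lower number from compound 1 to compound 2 (0.15 log units; within the scatter). Neither reached beyond the scatter, and the change to compound 4 is of the same kind, so no step beyond the scatter is expected in this assay, with at most a slightly lower number. Compound 4 is therefore estimated at 36000 nM, within a range from 15000 nM to 85000 nM, which would mean an expected step of a 1.5-fold lower number from compound 1 to compound 4 (0.17 log units; within the scatter).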

Compound 4, half-maximal inhibitory concentration: 25400 nM
Compound 4: the middle estimate sits 1.4-fold (0.15 log units) above what was measured; the measured number falls inside the stated range.
By their numbers in this assay, from the lowest: compounds 4, 2, 3 and 1 (each within the scatter of the next, the first and the last beyond it).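

In this assay, among the compounds shown here, 3-chloro-4-fluorophenyl in place of 4-methylphenyl on the amide-type nitrogen gives a 2.1-fold lower number from compound 1 to compound 4 (0.33 log units; beyond the scatter), the first step at this position to clear the scatter. The chloro cannot be credited on its own: chloro in place of hydrogen on an aromatic carbon gives a 1.6-fold lower number from compound 3 to compound 4 (0.19 log units; within the scatter), and chloro in place of fluoro gives a 1.5-fold lower number from compound 2 to compound 4 (0.18 log units; within the scatter), so compounds 2, 3 and 4 remain indistinguishable and only compound 4 separates from compound 1. Nothing measured here explains this step. The compounds shown leave open how a phenyl ring carrying only chloro, or carrying methoxy or trifluoromethyl, would behave on this nitrogen. They also leave open whether a carbonyl in place of the thiocarbonyl would shift the number.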